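The source may report more compounds than this note shows. Statements on the series, on what has been measured and on what is new or still open speak of the compounds shown alone.

Compound 1 `NC(=O)c1cc2c(Cc3ccccc3)n[nH]c2cc1O` carries a plain primary amide on the shared core, and in a functional assay on A2780 cells (Homo sapiens) for antiproliferative activity, read by resazurin assay, with a stated time of 72 h (a lower number here means a stronger inhibitor, a higher number a weaker inhibitor), compound 1 has the entry "not determined" (no result reported). Compound 2 `CCCN(C)C(=O)c1cc2c(Cc3ccccc3)n[nH]c2cc1O`, a tertiary amide, gives > 10000 nM in this assay, and this is a limit of the assay rather than a number. Compound 3 `CN(Cc1ccccc1)C(=O)c1cc2c(Cc3ccccc3)n[nH]c2cc1O` changes that amide side chain: phenyl in place of ethyl on a saturated chain carbon bound to an amide-type nitrogen. Among the compounds with values here, with no measured step to draw on, the expected step of an at least 1.1-fold lower number from compound 2 to compound 3 (0.04 log units; that floor lies within the scatter) is small, toward a stronger inhibitor. For compound 3 the estimated value is 9000 nM, with an expected range from 2500 nM to 30000 nM.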

Compound 3, half-maximal inhibitory concentration: 980 nM
Compound 3: the middle estimate sits 9.2-fold (0.96 log units) above what was measured; the measured number lies below the stated range.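

In this assay, changing propyl to benzyl on the amide side chain gives an at least 10-fold lower number from compound 2 to compound 3 (1.00 log units; beyond the scatter), so a single change at this place can move the result beyond the scatter. For compound 2, > 10000 nM is a limit of the assay and not a number. The true size of the step stays unknown because it starts from that limit: the limit of > 10000 nM in this assay, at which 1 of the 3 values shown sits.

Going by these compounds, whether a phenethyl group, with its longer chain, or a benzyl group carrying a methoxy group would do the same remains open. So does the effect of placing an amine in this side chain.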